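Lengthening a Side Chain on a Shared Core

This account rests on a few compounds, and the source may have more. Where it says the series, first, only, none or still open, it means among the compounds named here.

Of the compounds shown here, two on a shared core have been tested in a functional assay on EL4 cells (Mus musculus) for antiproliferative activity, read by sulforhodamine B assay, with a stated time of 48 h; a higher number here means a weaker inhibitor, a lower number a stronger inhibitor. Compound 1 `CC(C)(C)OC(=O)NCCC[C@@H]1N=C2C[C@@H]3C[C@@H](C3(C)C)[C@]2(C)OC1=O` gives 4100 nM. Compound 2 `C[C@H]1N=C2C[C@H]3C[C@H](C3(C)C)[C@@]2(C)OC1=O` gives 27000 nM, the higher of the two numbers, so compound 2 stands as the weaker inhibitor, beyond the scatter from compound 1. Compound 3 `CC1(C)[C@H]2CC3=N[C@H](CCC(=O)O)C(=O)O[C@]3(C)[C@@H]1C2` differs from compound 2 by carboxymethyl in place of hydrogen on a saturated chain carbon bound to a saturated ring carbon. Among the compounds with values here, no measured pair shows this exact change. Guided only by the lower number of compound 1 at 4100 nM, a modest step toward a lower number is expected, a 2.3-fold lower number from compound 2 to compound 3 (0.35 log units; beyond the scatter). Compound 3 is therefore estimated at 12000 nM, within a range from 3000 nM to 50000 nM.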

Compound 3, half-maximal inhibitory concentration: 30000 nM
Beside the measured number, compound 3's estimate is 2.5-fold (0.40 log units) below it; the measured number falls inside the stated range.
By their numbers in this assay, from the lowest: compound 1; then compounds 2 and 3 (each within the scatter of the next).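

Within this assay the swap of hydrogen for carboxymethyl on this saturated chain carbon gives a 1.1-fold higher number from compound 2 to compound 3 (0.05 log units; within the scatter) and so leaves the number unchanged within the usual scatter. At this position, then, the added chain and its carboxylic acid end produce no measurable shift in either direction. Nothing available here explains this outcome. From the compounds shown here alone, whether a free amine at the end of this chain would move the number remains open. So does the effect of a longer chain ending in a carboxylic acid.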